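A few compounds are considered here, and "the series" means these few. Any claim that something is new, unique, unknown or untested is made for them only; others in the source may bear on it.

Measured so far:
compound 1, `CCOC(=O)C1=CCCCC1S(=O)(=O)Cc1ccsc1`, in a functional assay on RAW264.7 cells (Mus musculus), read by fluorescence (on this read-out lower numbers stand for stronger inhibition and higher numbers for weaker inhibition), compound 1 gives 105 nM;
compound 2, `CC(C)OC(=O)C1=CCCCC1S(=O)(=O)Cc1ccc(F)cc1Cl`, in this assay compound 2 gives 100 nM.

Compound 2 has the lower of the two numbers, but the gap to compound 1 is so small that it lies within the usual scatter of repeated measurements, so the two cannot be told apart on these figures. For the measured compounds named here, both share the same core, a ring bearing a sulfonyl-linked benzyl-type arm and a carbonyl group, and differ from each other in two places at once, so no single-change step between measured compounds is available.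

Compound 3, `CCCC(=O)C1=CCCCC1S(=O)(=O)Cc1ccc(F)cc1Cl`, is not yet measured. It differs from compound 2 in one place only: propyl in place of isopropoxy on a carbonyl carbon. Going by the values given here, no measured pair shows what such a change at the carbonyl does, so the direction of the step is open. A modest shift is expected rather than a large one, with a slight lean toward a higher number, and the estimated step from compound 2 to compound 3 is a 2.0-fold higher number from compound 2 to compound 3 (0.30 log units; within the scatter). For compound 3 in this assay the expected value is 200 nM, with a range from 60 nM to 700 nM.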

Compound 3, half-maximal inhibitory concentration: 11 nM
Beside the measured number, compound 3's estimate is 18-fold (1.26 log units) above it; the measured number lies below the stated range.
By their numbers in this assay, from the lowest: compound 3; then compounds 2 and 1 (each within the scatter of the next).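

Until now, the two measured compounds differed in two places at once, so nothing could be said about the carbonyl carbon on its own. Compound 3 supplies the first single change: in this assay, propyl in place of isopropoxy on that carbon gives a 9.1-fold lower number from compound 2 to compound 3 (0.96 log units; beyond the scatter) while the rest of the molecule stays the same, so the group on this carbonyl carbon clearly influences inhibition, and here the swap strengthens it. The swap removes isopropoxy, with its oxygen and its hydrogen-bond acceptor, and brings in propyl, which has only carbon and no acceptor, but no measurement at hand explains why the number falls.

This single pair cannot separate the loss of the oxygen from the change in chain shape, since both happen in the same step, and it cannot show whether the gain would carry over to the arm of compound 1. An ethyl group, a longer chain such as butyl, or an amine on the same carbonyl carbon would remain to be compared before any trend at this position could be described.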